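A few compounds are considered here, and "the series" means these few. Any claim that something is new, unique, unknown or untested is made for them only; others in the source may bear on it.

Of the compounds shown here, three have so far been tested in a functional assay on the whole organism (strain albino) for inhibition, with Rattus norvegicus as the target, read by paw edema, with stated times of 30 min and 1 h, at a dose of 5 mg/kg by the oral route; a lower number here means less inhibition, a higher number more inhibition at the dose given (going by the name of the read-out). Compound 1, with the structure `CCOC(=O)Cc1nc(N)n(C(=O)c2ccc(Cl)cc2)n1`, gives 34.2% in this assay. Compound 2, with the structure `CCOC(=O)Cc1nc(N)n(C(=O)c2ccc(Br)cc2)n1`, gives 34.8%. Compound 3, with the structure `CCOC(=O)Cc1n[nH]c(NC(=O)c2ccc(Cl)cc2)n1`, gives 31.1%. Compounds 1 and 2 differ in a single spot: bromo in place of chloro on an aromatic carbon. That exchange produced a number 0.6 percentage points higher from compound 1 to compound 2 (within the scatter), so the two numbers cannot be told apart. Compounds 1 and 3 are built from the same atoms joined differently, and the difference between their two cores is not broken down here; their values in this assay lie within the scatter of each other as well.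

Compound 4, with the structure `CCOC(=O)Cc1n[nH]c(NC(=O)c2ccc(Br)cc2)n1`, has not yet been tested in this assay. It is related to compound 3 in the same way that compound 2 is related to compound 1: bromo in place of chloro on an aromatic carbon. The place of the exchange reads the same in both pairs, so this is the same change made on a second core. Because the earlier exchange gave a number 0.6 percentage points higher from compound 1 to compound 2 (within the scatter), the expectation is that this second one will also move the read-out little. The step is estimated as a number 0.6 percentage points higher from compound 3 to compound 4 (within the scatter). Compound 4 is therefore expected to give about 31.7% in this assay, most likely between 24% and 40%. The measured value will show whether the exchange behaves the same way here.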

Compound 4, a percentage reported as inhibition, in the whole organism at one dose (the size of the read-out at that dose, not a potency): 31.3%
Estimate against measurement, compound 4: 0.4 percentage points above, within the range that was stated.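

Exchanging chloro for bromo on the second core gave a number 0.2 percentage points higher from compound 3 to compound 4 (within the scatter) in this assay, and set beside the same exchange on the first core, the two steps agree: the same change on two cores in this assay, a number 0.6 percentage points higher (within the scatter) from compound 1 to compound 2 and a number 0.2 percentage points higher (within the scatter) from compound 3 to compound 4, 0.4 percentage points apart, within the scatter of two such steps

This shows that, on these two cores, going from 4-chlorophenyl to 4-bromophenyl carries over as a step too small to be told from no change at all. It does not show that the two cores respond alike in general, since two small steps that match are a weak test, resting on two pairs of compounds and on a single oral dose that gives the size of the effect and not a potency.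

The compounds shown hold only chloro or bromo on the aromatic ring, so it remains open whether a different group there, such as an amine or a methoxy group, would move the read-out beyond the scatter, and whether such a step would then carry over from one core to the other. The ethyl ester is also the same throughout, which leaves open what a carboxylic acid or a longer chain in its place would do.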